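The source may hold more compounds than are shown below. What is called first, only, known or untested is meant among the compounds shown, and "the series" means these compounds.

Compound 1 `CCc1cccc2c(OC)c(-c3occ(C)c3C(=O)OC)ccc12` gave 1.5 ug/mL in a functional assay on A549 cells (Homo sapiens) for cytotoxicity, read by MTT assay, with a stated time of 72 h; a higher number here means that more compound is needed for the effect, a lower number that less compound is needed.
Compound 2 `CCOC(=O)c1c(C)coc1-c1ccc2c(CC)cccc2c1OC` gave 3.8 ug/mL in this assay.
Compound 3 `CCc1cccc2c(OC)c(-c3occ(C)c3COC)ccc12` gave > 10 ug/mL in this assay.

For compound 3 the entry > 10 ug/mL is a limit of the assay, not a number (the limit of > 10 ug/mL in this assay, at which 1 of the 3 values shown sits). Compound 4 `CCOc1c(-c2occ(C)c2COC)ccc2c(CC)cccc12` has not yet been measured in this assay. It differs from compound 3 by methyl in place of hydrogen on a saturated chain carbon bound to an oxygen on an aromatic ring. The same kind of change was made from compound 1 to compound 2, (methyl in place of hydrogen on a saturated chain carbon bound to an oxygen next to a carbonyl group), where the step was a 2.5-fold higher number from compound 1 to compound 2 (0.40 log units; beyond the scatter). The two places are not the same: in the measured pair the saturated chain carbon is bound to an oxygen next to a carbonyl group, in the new pair to an oxygen on an aromatic ring. The cores also differ: compound 3 differs from compound 1 by methoxymethyl in place of methoxycarbonyl on an aromatic carbon, which gave an at least 6.6-fold higher number from compound 1 to compound 3 (0.82 log units; beyond the scatter). The step expected for the new pair is estimated as a step that the limit leaves unreadable from compound 3 to compound 4, resting on a 2.5-fold higher number from compound 1 to compound 2 (0.40 log units; beyond the scatter). With compound 3 already at a limit, compound 4 is expected to give about 18 ug/mL, likely between 8 ug/mL and 50 ug/mL, most probably again reported only as a limit.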

Compound 4, concentration for half-maximal effect: > 10 ug/mL
Compound 4: no number, only a limit (the forecaster's own chance of this, stated with the estimate: 75%); the middle value lies beyond the limit too.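

Compound 3 and compound 4 are both reported only as a limit, not as a number, so no step between them can be read in this assay: the limit of > 10 ug/mL in this assay, at which 2 of the 4 values shown sit.

The compounds shown leave open whether methyl in place of hydrogen on a saturated chain carbon bound to an oxygen on an aromatic ring changes the number at all for this pair.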